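The compounds below may be only part of what the source reports. "The series", "measured", "known", "first", "only" and "open" are said of these compounds alone.

In a functional assay on A549 cells (Homo sapiens) for cytotoxicity, read by sulforhodamine B assay, with a stated time of 48 h (a lower number here means a stronger inhibitor, a higher number a weaker inhibitor), compound 1 `COc1ccc2c(c1)c(/C=N/O)cn2Cc1cn([C@@H]2O[C@H](COC(C)=O)[C@@H](OC(C)=O)[C@H](OC(C)=O)[C@H]2OC(C)=O)nn1` gives > 200000 nM, which is a limit of the assay and not a number (the limit of > 200000 nM in this assay, at which 1 of the 3 values shown sits). Compound 2 `CC(=O)OC[C@H]1O[C@@H](n2cc(CN3C(=O)/C(=C\c4ccccc4)c4ccccc43)nn2)[C@H](OC(C)=O)[C@@H](OC(C)=O)[C@@H]1OC(C)=O` gives 17900 nM in this assay, and compound 3 `CC(=O)OC[C@H]1O[C@@H](n2cc(CN3C(=O)/C(=C/c4ccccc4)c4ccccc43)nn2)[C@H](OC(C)=O)[C@@H](OC(C)=O)[C@@H]1OC(C)=O` gives 20600 nM. The step of a 1.2-fold higher number from compound 2 to compound 3 (0.06 log units; within the scatter) lies within the scatter, and the two compounds differ in nothing but the configuration as drawn (the fact that compounds 2 and 3 differ only in the configuration as drawn). Compound 2 thus carries the lower of the two numbers recorded, but its gap to compound 3 is no larger than repeated measurements of the same compound would show.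

Compound 4 `COc1ccc(/C=C2\C(=O)N(Cc3cn([C@@H]4O[C@H](COC(C)=O)[C@@H](OC(C)=O)[C@H](OC(C)=O)[C@H]4OC(C)=O)nn3)c3ccccc32)cc1OC` is reached from compound 2 by the change (3,4-dimethoxyphenyl in place of phenyl on a double-bonded chain carbon bound to a double-bonded ring carbon). Going by the values given here, no measured step touches this kind of exchange: the only step recorded, from compound 2 to compound 3, swaps the drawn geometry of a double bond and leaves the number within the scatter. Nothing recorded therefore argues for a step in either direction, and the expectation for compound 4 is a step of a 1.0-fold higher number from compound 2 to compound 4 (0.00 log units; within the scatter) of no size beyond the scatter. Compound 4 is thus expected to give about 18000 nM in this assay, with a plausible range from 6000 nM to 55000 nM.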

Compound 4, half-maximal inhibitory concentration: 23300 nM
Estimate against measurement, compound 4: 1.3-fold (0.11 log units) below; the measured number falls inside the stated range.
By their numbers in this assay, from the lowest: compounds 2, 3 and 4 (each within the scatter of the next). At a limit, above all of these: compound 1.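

Going by these compounds alone, putting 3,4-dimethoxyphenyl in place of phenyl on a double-bonded chain carbon bound to a double-bonded ring carbon is the first exchange of a group at this place, and in this assay it gives a 1.3-fold higher number from compound 2 to compound 4 (0.11 log units; within the scatter) for this pair. This place therefore accepts a group of 10 heavy atoms in place of 6, now carrying hydrogen-bond acceptors, with a number that cannot be told apart from that of compound 2. Nothing shown here offers a reason for this result.

Going by these compounds, a single exchange cannot speak for every group at this place, so it remains open whether a carboxylic acid or an amine on the same aromatic ring would give a step beyond the scatter. Also open, on these data alone, is what free hydroxyl groups in place of the acetate groups of the shared core would do to the number in this assay, and whether any such exchange would hold for cells other than these.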